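Methyl to methoxy on the pendant phenyl ring

A few compounds are considered here, and "the series" means these few. Any claim that something is new, unique, unknown or untested is made for them only; others in the source may bear on it.

The series shares one core, varied at the pendant phenyl ring and at the anilide. For the measured compounds named here, compound 2 `Cc1ccc(-c2ccnc(C(=O)Nc3ccc(Oc4ccnc5[nH]ccc45)c(F)c3)c2)cc1` gives the lower of the two values known so far: in a functional assay on PC-3 cells (Homo sapiens) for cytotoxicity, read by MTT assay, with a stated time of 72 h (on this read-out lower numbers stand for stronger inhibition and higher numbers for weaker inhibition), compound 2 gives 3970 nM, whereas compound 1 `COc1ccc(-c2ccnc(C(=O)Nc3ccc(Oc4ccnc5[nH]ccc45)cc3)c2)cc1` gives 9620 nM, a gap beyond the usual scatter. Compound 3 `COc1ccc(-c2ccnc(C(=O)Nc3ccc(Oc4ccnc5[nH]ccc45)c(F)c3)c2)cc1` is compound 2 with one change, (methoxy in place of methyl on an aromatic carbon). Going by the values given here, no measured pair shows this change alone. Compound 3 is expected to sit near compound 2 or somewhat higher, a step of a 1.5-fold higher number from compound 2 to compound 3 (0.18 log units; within the scatter), with the higher value of compound 1 9620 nM as the only hint. The estimate for compound 3 in this assay is 6000 nM, within 2500 nM to 15000 nM.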

Compound 3, half-maximal inhibitory concentration: 20 nM
For compound 3 the middle estimate is 300-fold (2.48 log units) above the measured one; the measured number lies below the stated range.
By their numbers in this assay, from the lowest: compound 3; then compound 2; then compound 1.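

In this assay the 4-methylphenyl to 4-methoxyphenyl change alone gives a 200-fold lower number from compound 2 to compound 3 (2.30 log units; beyond the scatter) and shows that the group on this carbon, para to a large group, strongly shapes the value. With methoxy held constant, fluoro in place of hydrogen on the anilide gives a 480-fold lower number from compound 1 to compound 3 (2.68 log units; beyond the scatter) and so shows a second sensitive site. Compound 1 and compound 2 differ in two places, so their values alone could separate neither contribution.

No data bearing on the origin of either step are available. Going by these compounds, whether ethoxy, a dimethylamino group or chlorine on this carbon would keep the low value remains open.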